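The source may hold more compounds than are shown below. What is called first, only, known or untested is meant among the compounds shown, and "the series" means these compounds.

In a physicochemical assay for solubility, read by HPLC, at pH 7.4 (a higher number here means a more soluble compound, a lower number a less soluble compound), compound 1 (`CCCCCCCc1cc(=O)c2cc([N+](=O)[O-])ccc2[nH]1`) gives < 5000 nM, which is a limit of the assay and not a number. Compound 2 (`CCCCCOCc1cc(=O)c2cc([N+](=O)[O-])ccc2[nH]1`) gives 15000 nM. Within the data shown here, the one measured step, an at least 3.0-fold higher number from compound 1 to compound 2 (0.47 log units; beyond the scatter), lies beyond the scatter, but it starts from the limit of < 5000 nM in this assay, at which 1 of the 2 values shown sits, and changes the chain. Compound 3 (`CCCCCCCc1[nH]c2ccc([N+](=O)[O-])cc2c(=O)c1C(=O)O`) instead changes the core of compound 1: carboxy in place of hydrogen on an aromatic carbon. That measured step therefore bears on it only loosely, and a rise of similar or somewhat larger size is expected, namely an at least 6.0-fold higher number from compound 1 to compound 3 (0.77 log units; beyond the scatter). For compound 3, the estimated value is 30000 nM, within an expected range of 8000 nM to 100000 nM.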

Compound 3, solubility: 15000 nM
Beside the measured number, compound 3's estimate is 2.0-fold (0.30 log units) above it, within the range that was stated.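

With the heptyl group kept, carboxy in place of hydrogen on this aromatic carbon gives an at least 3.0-fold higher number from compound 1 to compound 3 (0.47 log units; beyond the scatter) and so shows that a change on the core, not only in the chain, can go with a higher number in this assay here. Compound 1 gives < 5000 nM as a limit of the assay and not a number. From the compounds shown here alone, the true size of this step therefore stays unknown, because it starts from a limit: the limit of < 5000 nM in this assay, at which 1 of the 3 values shown sits.

Going by these compounds, whether an amine or an ester on this same carbon goes with a step of similar size stays open. So does whether carboxy gives a similar rise with a longer chain.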